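Replacing a Nitro Group with Hydroxy on a Biaryl Core

The source may report more compounds than this note shows. Statements on the series, on what has been measured and on what is new or still open speak of the compounds shown alone.

Measured compounds:
- Compound 1, `CC(Oc1ccccc1-c1ccc([N+](=O)[O-])cc1)C1=NCCN1`: 302 nM
- Compound 2, `Cc1ccc(-c2ccccc2OC(C)C2=NCCN2)cc1`: 251 nM
- Compound 3, `Cc1cccc(-c2ccccc2OC(C)C2=NCCN2)c1`: 245 nM

In an assay on CHO cells for displacement of a labelled ligand from Alpha-2C adrenergic receptor (Homo sapiens) (on this read-out lower numbers stand for stronger inhibition and higher numbers for weaker inhibition), the three numbers lie close together. Among the compounds with values here, compound 1 and compound 2 differ by a 1.2-fold lower number from compound 1 to compound 2 (0.08 log units; within the scatter), and the gap between compound 1 and compound 3 is of the same small size, so no compound among them can be set apart from the others.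

The new compound 4, `CC(Oc1ccccc1-c1ccc(O)cc1)C1=NCCN1`, differs from compound 1 in one place: hydroxy in place of nitro on an aromatic carbon.

Within the data shown here, the only measured step that touches the same position is the one from compound 1 to compound 2, where methyl took the place of nitro with a 1.2-fold lower number from compound 1 to compound 2 (0.08 log units; within the scatter). The step from compound 2 to compound 3, a 1.0-fold lower number from compound 2 to compound 3 (0.01 log units; within the scatter), only moves the methyl and says nothing about hydroxy. With just one step at this position, and none showing hydroxy anywhere, the expectation for compound 4 must stay cautious: no shift beyond the scatter, with a wide range. Compound 4 is therefore estimated at 300 nM, between 100 nM and 900 nM, which would mean a step of a 1.0-fold lower number from compound 1 to compound 4 (0.00 log units; within the scatter).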

Compound 4, inhibition constant: 331 nM
Compound 4: the middle estimate sits 1.1-fold (0.04 log units) below what was measured; the measured number falls inside the stated range.
By their numbers in this assay, from the lowest: compounds 3, 2, 1 and 4 (each within the scatter of the next).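

In this assay, hydroxy can take the place of nitro on this aromatic carbon with a 1.1-fold higher number from compound 1 to compound 4 (0.04 log units; within the scatter), even though the change swaps 3 heavy atoms and 0 hydrogen-bond donors for 1 heavy atom and 1 hydrogen-bond donor. Hydroxy in place of methyl gives a 1.3-fold higher number from compound 2 to compound 4 (0.12 log units; within the scatter), and 4-hydroxyphenyl in place of 3-methylphenyl gives a 1.4-fold higher number from compound 3 to compound 4 (0.13 log units; within the scatter), so nitro, methyl and hydroxy on this ring cannot be told apart in this read-out. Nothing available explains why these groups read alike.

Going by these compounds, every group seen on this ring so far stays within the scatter, so it remains open whether any group there can shift the number at all. A carboxylic acid, an amine or a longer alkoxy chain at this place would test that.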